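The source may hold more compounds than are shown below. What is called first, only, known or untested is meant among the compounds shown, and "the series" means these compounds.

Compounds measured in an assay on cells for activation of Cystic fibrosis transmembrane conductance regulator (Homo sapiens), read by fluorescence, with a stated time of 10 min; a higher number here means that more compound is needed for the effect, a lower number that less compound is needed:
- compound 1 `CCn1c(=O)c(-c2cccc([N+](=O)[O-])c2)nc2ccccc21`: 65 nM
- compound 2 `O=c1c(-c2cccc([N+](=O)[O-])c2)nc2ccccc2n1Cc1ccco1`: 20 nM

Compound 2 has the lowest number of the two, with compound 1 giving a 3.3-fold lower number from compound 1 to compound 2 (0.51 log units; beyond the scatter). Compound 3 `O=c1c(-c2cccc([N+](=O)[O-])c2)nc2ccccc2n1Cc1cccs1` differs from compound 2 by thiophen-2-yl in place of furan-2-yl on a saturated chain carbon bound to an aromatic nitrogen. Among the measured compounds shown here, no measured step covers this swap directly; the only measured step, a 3.3-fold lower number from compound 1 to compound 2 (0.51 log units; beyond the scatter), shows that a five-membered aromatic ring at this position is accepted. The thiophene is therefore expected to give a number close to that of compound 2, within the usual scatter, so for compound 3 the expected step is a 1.3-fold lower number from compound 2 to compound 3 (0.12 log units; within the scatter), with an estimate of 15 nM in this assay, between 6 nM and 45 nM.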

Compound 3, half-maximal effective concentration: 10 nM
Estimate against measurement, compound 3: 1.5-fold (0.18 log units) above, within the range that was stated.
By their numbers in this assay, from the lowest: compounds 3 and 2 (each within the scatter of the next); then compound 1.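

At the saturated chain carbon bound to an aromatic nitrogen, thiophen-2-yl and furan-2-yl cannot be told apart in this assay, since a 2.0-fold lower number from compound 2 to compound 3 (0.30 log units; within the scatter) stays within the scatter. Measured against methyl, thiophen-2-yl gives a 6.5-fold lower number from compound 1 to compound 3 (0.81 log units; beyond the scatter), so the step away from methyl seen with furan-2-yl also holds for a second five-membered aromatic ring. No measured evidence bears on the reason for this. The compounds shown leave open whether a phenyl ring, an amine or a longer chain at this place would give numbers like these.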